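This account rests on a few compounds, and the source may have more. Where it says the series, first, only, none or still open, it means among the compounds named here.

Compound 1 `COc1cc(-c2cc(/C=C/C(=O)c3ccc(N)cc3)[nH]n2)cc(OC)c1OC` and compound 2 `COc1ccc(C(=O)/C=C/c2cc(-c3cc(OC)c(OC)c(OC)c3)n[nH]2)cc1OC` share a core and differ only in the group on the carbonyl carbon. In a functional assay on UACC-257 cells (Homo sapiens) for inhibition, read by sulforhodamine B assay, with a stated time of 48 h (a higher number here means a weaker inhibitor of growth, a lower number a stronger inhibitor of growth), compound 1 gives 4020 nM, and compound 2 gives 2830 nM. The step between them, a 1.4-fold lower number from compound 1 to compound 2 (0.15 log units; within the scatter), leaves compound 2 with the lower of the two numbers shown, though not set apart from compound 1. Compound 3 `COc1cc(C(=O)/C=C/c2cc(-c3cc(OC)c(OC)c(OC)c3)n[nH]2)cc(OC)c1OC` arises from compound 2 by methoxy in place of hydrogen on an aromatic carbon. Going by the values given here, no measured step adds a methoxy group; the only step available, a 1.4-fold lower number from compound 1 to compound 2 (0.15 log units; within the scatter), was small, so no change beyond the scatter is expected in this assay. Compound 3 is therefore estimated at 2800 nM, between 1000 nM and 8000 nM, an expected step of a 1.0-fold lower number from compound 2 to compound 3 (0.00 log units; within the scatter).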

Compound 3, concentration for total growth inhibition: 2990 nM
Compound 3: middle estimate off by 1.1-fold (0.03 log units), on the low side; the range from low to high includes it.
By their numbers in this assay, from the lowest: compounds 2, 3 and 1 (each within the scatter of the next).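

Adding methoxy in place of hydrogen, ortho to a methoxy group on this six-membered aromatic ring, gives a 1.1-fold higher number from compound 2 to compound 3 (0.02 log units; within the scatter) in this assay. Going by these compounds alone, this is the first measured step that adds a group at this place, and it shows that the added methoxy leaves the number within the scatter. No measured evidence offers an explanation for this result.

On these data alone, whether a hydroxyl group or a longer chain such as ethoxy at this place would move the number beyond the scatter remains open.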